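This account rests on a few compounds, and the source may have more. Where it says the series, first, only, none or still open, it means among the compounds named here.

Series in a functional assay on HT cells (Homo sapiens) for antiproliferative activity, read by fluorescence, with a stated time of 72 h; on this read-out higher numbers stand for weaker inhibition of growth and lower numbers for stronger inhibition of growth:
compound 1 `CC(C)c1n[nH]c2c(NCc3ccc(-c4ccccn4)cc3)nc(SCC(O)CO)nc12`: 21 nM
compound 2 `CC(C)c1n[nH]c2c(NCc3ccc(-c4ccccn4)cc3)nc(SC(CO)C(C)C)nc12`: 980 nM
compound 3 `CNCCSc1nc(NCc2ccc(-c3ccccn3)cc2)c2[nH]nc(C(C)C)c2n1`: 56 nM

Compound 3 holds the second highest of the three numbers and lies closer to compound 1 than to compound 2. The next analogue is compound 4 `COCSc1nc(NCc2ccc(-c3ccccn3)cc2)c2[nH]nc(C(C)C)c2n1`, with this change: methoxy in place of (methylamino)methyl on a saturated chain carbon bound to a sulfur. Changes to the group on the sulfur have already given a 2.7-fold higher number from compound 1 to compound 3 (0.43 log units; beyond the scatter), a 47-fold higher number from compound 1 to compound 2 (1.67 log units; beyond the scatter) and an 18-fold lower number from compound 2 to compound 3 (1.24 log units; beyond the scatter). Among the compounds with values here, none of the measured compounds carries methoxy, so the size is uncertain. A modest step toward a higher number is expected in this assay, and a large one is not excluded. The expected step is a 2.9-fold higher number from compound 3 to compound 4 (0.46 log units; beyond the scatter). For compound 4 the estimated value is 160 nM, with an expected range of 45 nM to 600 nM.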

Compound 4, concentration for 50% growth inhibition: 340 nM
Estimate against measurement, compound 4: 2.1-fold (0.33 log units) below; the measured number falls inside the stated range.
By their numbers in this assay, from the lowest: compound 1; then compound 3; then compound 4; then compound 2.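

In this assay, methoxy in place of (methylamino)methyl on a saturated chain carbon bound to a sulfur gives a 6.1-fold higher number from compound 3 to compound 4 (0.78 log units; beyond the scatter), so at this position the methoxymethyl group does not match the 2-(methylamino)ethyl group. The same group gives a 16-fold higher number from compound 1 to compound 4 (1.21 log units; beyond the scatter) against the 2,3-dihydroxypropyl compound, yet a 2.9-fold lower number from compound 2 to compound 4 (0.46 log units; beyond the scatter) against the 1-(hydroxymethyl)-2-methylpropyl compound, so it places between them. No supporting data on the origin of these steps are available. Open, as far as these compounds go, is whether the higher number follows the shorter chain or the oxygen in place of nitrogen. A 2-methoxyethyl group on the sulfur would separate the two.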